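The compounds below may be only part of what the source reports. "The series", "measured", "known", "first", "only" and "open" are said of these compounds alone.

Compound 1 `COc1cccc(Oc2ccc3c(NCCCNCc4cc(F)ccc4OC)ccnc3c2)c1` is the starting point of this step. In a physicochemical assay for acid dissociation, compound 1 gives 9.28. Two neighbours were measured alongside it: compound 2 `COc1ccc(Oc2ccc3c(NCCCNCc4cccc(OC)c4O)ccnc3c2)cc1` gives 9.28 in this assay, and compound 3 `COc1cccc(Oc2ccc3c(NCCCNCc4cccc(OC)c4O)ccnc3c2)c1` gives 9.28. Compound 1 therefore stands level with both at the digits shown. The step of no change at the digits printed from compound 1 to compound 3 (within the scatter) touched the aryl group on the saturated chain carbon bound to an amine nitrogen, while the step of no change at the digits printed from compound 2 to compound 3 (within the scatter) touched the aryl group on the ether oxygen; neither moved the read-out beyond the scatter.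

Compound 4 `COc1ccc(F)cc1CNCCCNc1ccnc2cc(-c3ccc(F)cc3)ccc12` has not been measured. It differs from compound 1 in this way: 4-fluorophenyl in place of 3-methoxyphenoxy on an aromatic carbon. Among the compounds with values here, no measured step changed that position of the core, so the two steps bear on it only indirectly, through showing that changes to the peripheral aryl groups left the value unmoved. On that basis the step is expected to be no change at the digits printed from compound 1 to compound 4 (within the scatter), within the scatter. Compound 4 is estimated at 9.28, with a range from 8.85 to 9.7.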

Compound 4, acid dissociation constant: 9.47
Compound 4: the middle estimate sits 0.19 log units below what was measured; measured number inside the range.
By their numbers in this assay, from the lowest: compounds 1, 2, 3 and 4 (each within the scatter of the next).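

The earlier compounds shown here varied only the aryl groups, and none of them touched this aromatic carbon of the shared core. Here, in this assay, replacing 3-methoxyphenoxy with 4-fluorophenyl gives a number 0.19 log units higher from compound 1 to compound 4 (within the scatter), so the read-out stays within the scatter even when the change reaches this position and the oxygen atoms of the leaving group give way to a fluorine. Nothing available offers an explanation for this outcome.

The compounds shown leave open whether a group of a different kind on this aromatic carbon, such as an amine or a carboxylic acid, would also stay within the scatter. They also leave open whether a longer chain in place of the saturated chain would shift the value in this assay.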